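Swapping the aryl group on the oxazole core for half-life

The source may hold more compounds than are shown below. What is called first, only, known or untested is meant among the compounds shown, and "the series" means these compounds.

Measured so far:
compound 1, `Cc1ccccc1-c1nc(CN2CCC(C(=O)NCCCN3CCCC(C(C)C)C3)CC2)c(C)o1`, 0.323 h
compound 2, `Cc1oc(-c2c(Cl)cccc2C(F)(F)F)nc1CN1CCC(C(=O)NCCCN2C[C@H](C)C[C@H](C)C2)CC1`, 0.03 h

Both were measured in an ADME assay on microsomes from liver (Rattus norvegicus) for metabolic stability, read by LC-MS, using NADPH, at 37 degrees C; on this read-out higher numbers stand for a longer-lived compound and lower numbers for a shorter-lived compound. On these two numbers compound 2 stands lowest, and compound 1 gives a higher number that lies beyond the usual scatter. The two compounds differ in more than one place, so the pair cannot show how much of that gap comes from the aryl group alone.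

Compound 3, `COc1ccc(-c2nc(CN3CCC(C(=O)NCCCN4C[C@H](C)C[C@H](C)C4)CC3)c(C)o2)cc1OC`, keeps the rest of compound 2 and changes only the aryl group on the shared core: 3,4-dimethoxyphenyl in place of 2-chloro-6-(trifluoromethyl)phenyl on an aromatic carbon. For the measured compounds named here, no measured pair shows this exact change. With compound 1 as the only hint that a different aryl group can go with a longer half-life, the step is expected to go upward in this assay and to exceed the scatter, a 3.3-fold higher number from compound 2 to compound 3 (0.52 log units; beyond the scatter). For compound 3 the estimate is 0.1 h, with a range from 0.02 h to 0.5 h.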

Compound 3, half-life: > 0.5 h
Compound 3: a limit, no number; the forecaster's own chance of this, stated with the estimate: 5%; at least 5.0-fold (0.69 log units) between middle value and limit.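

Putting 3,4-dimethoxyphenyl in place of 2-chloro-6-(trifluoromethyl)phenyl, with the rest of the molecule unchanged, gives an at least 16-fold higher number from compound 2 to compound 3 (1.22 log units; beyond the scatter) in this assay. Compound 3 gives > 0.5 h, which is a limit of the assay and not a number. For the compounds shown here, compound 1 and compound 2 differ in more than one place, so this new pair is the first to tie a large gap in half-life to the aryl group on the shared core alone.

The step swaps the chlorine, the trifluoromethyl and the two methoxy groups all at once, so the compounds shown cannot say which of them matters. An unsubstituted phenyl, or a phenyl with a single methoxy group, could help separate the loss of the old substituents from the arrival of the new ones.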